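The source may hold more compounds than are shown below. What is called first, only, known or untested is meant among the compounds shown, and "the series" means these compounds.

Compound 1 `O=C(O)CCc1ccc(C#CC2CCCC2)cc1` gives 94% in a functional assay on 1321-N1 cells for agonist activity at Free fatty acid receptor 1 (Homo sapiens), read by calcium flux, with a stated time of 0.4 s; a higher number here means a larger maximal response, a lower number a smaller maximal response. Compound 2 `CC(C)=C(C)C#Cc1ccc(CCC(=O)O)cc1` gives 105%. Compound 3 `C/C=C(\C)C#Cc1ccc(CCC(=O)O)c(F)c1` gives 97%.

Of these three numbers compound 2 has the largest, but compound 3 lies within the usual scatter of it; only compound 1 sits beyond the scatter, the step being a number 11 percentage points higher from compound 1 to compound 2 (beyond the scatter). Compound 4 `O=C(O)CCc1ccc(C#CC2=CCCCC2)cc1` is not yet measured; it differs from compound 2 in one place: cyclohex-1-en-1-yl in place of 1,2-dimethylprop-1-en-1-yl on a triple-bonded carbon. For the measured compounds named here, the one measured step that bears on this, a number 11 percentage points higher from compound 1 to compound 2 (beyond the scatter), went from a ring to an open chain and gained modestly; here an open chain returns to a ring, so a small loss or no change beyond the scatter is expected. Compound 4 is therefore estimated at 97%, between 84% and 110%, a step of a number 8 percentage points lower from compound 2 to compound 4 (within the scatter).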

Compound 4, largest response reached (reported as efficacy), in percent of the reference or control that the assay uses: 100%
Compound 4: middle estimate off by 3 percentage points, on the low side, within the range that was stated.
By their numbers in this assay, from the lowest: compounds 1, 3, 4 and 2 (each within the scatter of the next, the first and the last beyond it).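

At this position, on a triple-bonded carbon, a ring can replace the open chain without a clear loss: in this assay the change to cyclohex-1-en-1-yl gives a number 5 percentage points lower from compound 2 to compound 4 (within the scatter). Set against cyclopentyl, the same group gives a number 6 percentage points higher from compound 1 to compound 4 (within the scatter), so compound 4 sits within the scatter of both, and having a ring or an open chain does not by itself set the response. Nothing available here explains these numbers.

As far as these compounds go, whether a saturated cyclohexyl ring or a piperidine ring, which carries an amine, would keep this response remains open. So does how cyclohex-1-en-1-yl would behave on the core of compound 3.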